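The source may report more compounds than this note shows. Statements on the series, on what has been measured and on what is new or still open speak of the compounds shown alone.

Measured in a functional assay on SK-OV-3 cells (Homo sapiens) for inhibition, read by sulforhodamine B assay, with a stated time of 48 h, tested at 10 uM; a lower number here means less inhibition of growth, a higher number more inhibition of growth at the concentration tested:
Compound 1 `COc1ccc(-c2nc3sc(-c4ccccc4)cn3n2)cc1`: 32%
Compound 2 `Clc1ccc(-c2cn3nc(-c4ccccc4)nc3s2)cc1`: 64%

Compound 2 stands higher of the two, and its gap to compound 1 lies beyond the scatter. Compound 3 `c1ccc(-c2nc3sc(-c4ccccc4)cn3n2)cc1` comes from compound 2 by a single change: hydrogen in place of chloro on an aromatic carbon. Among the measured compounds shown here, no measured pair shows this change alone, so the guide is thin. Compound 1 also lacks the chloro, though it differs elsewhere too, and gives 32%, so a moderate fall beyond the scatter is expected in this assay. The expected step is a number 19 percentage points lower from compound 2 to compound 3 (beyond the scatter). For compound 3 the estimated value is 45%, with an expected range of 25% to 65%.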

Compound 3, percent growth inhibition at one concentration: 5%
For compound 3 the middle estimate is 40 percentage points above the measured one; the whole stated range lies above it.
By their numbers in this assay, from the lowest: compound 3; then compound 1; then compound 2.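

Taking away the single chloro gives a number 59 percentage points lower from compound 2 to compound 3 (beyond the scatter) in this assay, so almost all the growth inhibition of compound 2 depends on this one atom on its 4-chlorophenyl group. Hydrogen in place of methoxy, on the other phenyl ring, gives a number 27 percentage points lower from compound 1 to compound 3 (beyond the scatter), so a group on either ring lifts inhibition above that of compound 3, the lowest of the three. No supporting data explain these falls.

From the compounds shown here alone, whether bromo, an amine or a carboxylic acid could replace the chloro remains open. So does how methoxy would behave at the chloro's place.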